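The compounds below may be only part of what the source reports. "The series", "measured", "known", "first", "only" and "open" are said of these compounds alone.

The measured compounds are these. Compound 1 `Cn1ncc(Cl)c1-c1cc(C(=O)NC2CNCCC2c2ccc(C(F)(F)F)cc2)oc1Cl` gives 7.2 nM in an assay for inhibition of RAC-alpha serine/threonine-protein kinase (Homo sapiens), read by HTRF, with a stated time of 1 h; on this read-out higher numbers stand for weaker inhibition and lower numbers for stronger inhibition. Compound 2 `C=CC[C@@H]1C[C@@H](c2ccc(Cl)c(Cl)c2)[C@H](NC(=O)c2cc(-c3c(Cl)cnn3C)c(Cl)o2)CN1` gives 12.4 nM in this assay. Compound 3 `O=C(N[C@@H]1CNCC[C@H]1c1ccc(Cl)cc1)c1ccc(-c2ncnc3c2CCC3O)s1` is reported in this assay only as > 1000 nM, which is a limit of the assay and not a number; that limit is the limit of > 1000 nM in this assay, at which 1 of the 3 values shown sits.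

Among the two numbers actually obtained, compound 2 and compound 1 sit within the usual scatter of each other, so nothing separates them. Compound 2 is the only one of the three carrying a small chain on its saturated ring, and compound 4 `COCC[C@@H]1C[C@@H](c2ccc(Cl)c(Cl)c2)[C@H](NC(=O)c2cc(-c3c(Cl)cnn3C)c(Cl)o2)CN1` keeps everything else of compound 2 while swapping that chain: methoxymethyl in place of vinyl on a saturated chain carbon bound to a saturated ring carbon. Read one bond further out, the change is allyl to 2-methoxyethyl. For the measured compounds named here, no measured pair in this set differs in just that way, so the size of the step has to be guessed. Going by the values given here, the replacing group is of similar length and adds one hydrogen-bond acceptor; with no comparable step measured, the expectation is a change of modest size or none beyond the scatter in this assay. The estimated step from compound 2 to compound 4 is a 1.2-fold higher number from compound 2 to compound 4 (0.08 log units; within the scatter). Compound 4 is therefore expected to give about 15 nM, between 5 nM and 45 nM.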

Compound 4, half-maximal inhibitory concentration: 7.01 nM
Compound 4: middle estimate off by 2.1-fold (0.33 log units), on the high side; the range from low to high includes it.
By their numbers in this assay, from the lowest: compounds 4, 1 and 2 (each within the scatter of the next). At a limit, above all of these: compound 3.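

In this assay, swapping methoxymethyl in place of vinyl on a saturated chain carbon bound to a saturated ring carbon gives a 1.8-fold lower number from compound 2 to compound 4 (0.25 log units; within the scatter) and so does not separate the two compounds. Until now, the only chain with a rest of this kind in the set was the allyl of compound 2; compound 4 shows that a 2-methoxyethyl chain, which has no double bond outside aromatic rings and brings in a hydrogen-bond acceptor, fits the same range of numbers, so at this position in this pair the read-out does not depend on either feature. Nothing measured here gives a reason why the two chains read alike.

The compounds shown carry only these two chains at this place, so it remains open whether an amine, a carboxylic acid or a much longer chain would be accepted there as well. From the compounds shown here alone, it is also open whether a plain methyl group, or a bare ring carbon, would keep the number close to that of compound 2 (12.4 nM) in this assay with the rest of the structure unchanged.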